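The compounds below may be only part of what the source reports. "The series", "measured", "known", "first", "only" and "open" are said of these compounds alone.

Working notes on the series. Among the measured compounds shown here, in a functional assay on DU-145 cells (Homo sapiens) for inhibition, read by MTT assay, with a stated time of 48 h (a higher number here means a weaker inhibitor, a lower number a stronger inhibitor), compound 2 `Cn1c(/C=C2\SC(=O)N(CC(=O)Nc3nc(-c4ccccc4)cs3)C2=O)nc2ccccc21` gives 31400 nM, the only actual number in this set. Compound 1 `CCn1c(/C=C2\SC(=O)N(CC(=O)Nc3cc(C(C)(C)C)on3)C2=O)nc2ccccc21` gives only a limit, > 50000 nM, a value that sits at the limit of > 50000 nM in this assay, at which 1 of the 2 values shown sits, rather than being a measured number. Compound 3 `CCn1c(/C=C2\SC(=O)N(CC(=O)Nc3nc(-c4ccccc4)cs3)C2=O)nc2ccccc21` has not yet been measured in this assay; it differs from compound 2 by methyl in place of hydrogen on a saturated chain carbon bound to an aromatic nitrogen, which is methyl in place of hydrogen on a saturated chain carbon bound to an aromatic nitrogen. For the measured compounds named here, no measured step between neighbours exists here, so the expected step of a 1.1-fold higher number from compound 2 to compound 3 (0.05 log units; within the scatter) is only a small one, in either direction, not beyond the usual scatter. Compound 3 is therefore expected at about 35000 nM, with a range from 15000 nM to 80000 nM.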

Compound 3, half-maximal inhibitory concentration: > 50000 nM
Compound 3 gave a limit, no number; the forecaster's own chance of this, stated with the estimate: 30%; middle value at least 1.4-fold (0.15 log units) from the limit.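

In this assay, among the compounds shown here, the change from 1-methyl-1H-benzimidazol-2-yl to 1-ethyl-1H-benzimidazol-2-yl gives the first step at this position: an at least 1.5-fold higher number from compound 2 to compound 3 (0.20 log units; that floor lies within the scatter). Going by these compounds, this is only a floor, so its true size stays unknown, but ethyl brings no sign of stronger inhibition. The step between compound 1 and compound 3 cannot be read, and the series now rests mostly on limits: the limit of > 50000 nM in this assay, at which 2 of the 3 values shown sit.

On these data alone, whether a longer chain such as propyl, or a chain ending in an amine or a carboxylic acid, would bring a value back inside the measurable range remains open.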